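The source may hold more compounds than are shown below. What is called first, only, known or untested is meant among the compounds shown, and "the series" means these compounds.

Values in a toxicity assay on MRC5 cells (Homo sapiens) for inhibition, read by MTT assay, with a stated time of 72 h; on this read-out lower numbers stand for stronger inhibition and higher numbers for weaker inhibition:

- Compound 1 `CCCCCCCCCCCCSCCc1ccc(OCc2ccc(OC)cc2)c(OCc2ccc(OC)cc2)c1`: > 50000 nM
- Compound 2 `CCCCCCCCCCCCCC(=O)OCCc1ccc(O)c(O)c1`: > 50000 nM
- Compound 3 `CCCCCCCCCCCCC(=O)OCCc1ccc(O)c(O)c1`: 13200 nM

The entries for compound 1 and compound 2 are limits of the assay, not numbers: the limit of > 50000 nM in this assay, at which 2 of the 3 values shown sit. Among the measured compounds shown here, compound 3, at 13200 nM, has the only true number in this assay.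

Compound 4 `CCCCCCCCCCCCCCCC(=O)OCCc1ccc(O)c(O)c1` is reached from compound 3 by propyl in place of hydrogen on a saturated chain carbon, ten or more bonds along the chain from a carbonyl carbon. For the measured compounds named here, one measured step bears on this change: an at least 3.7-fold lower number from compound 2 to compound 3 (0.57 log units; beyond the scatter), where hydrogen replaced methyl on the same kind of chain carbon. The new change runs the opposite way, adding to the chain, so a higher number is expected, possibly one that reaches the limit. The expected change is a 4.2-fold higher number from compound 3 to compound 4 (0.62 log units; beyond the scatter). For compound 4 the estimated value is 55000 nM, with an expected range of 25000 nM to 120000 nM.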

Compound 4, half-maximal inhibitory concentration: > 50000 nM
Compound 4 was reported as a limit (the forecaster's own chance of this, stated with the estimate: 75%); the middle value lies beyond the limit too.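

Adding propyl on this saturated chain carbon gives an at least 3.7-fold higher number from compound 3 to compound 4 (0.57 log units; beyond the scatter), so in this assay the change seen when a methyl was removed now also holds for a larger addition to the chain. Going by these compounds, compound 4 is a limit, so the true size of this step stays unknown: the limit of > 50000 nM in this assay, at which 3 of the 4 values shown sit. The step from compound 2 to compound 4 cannot be read.

On these data alone, it stays open whether a shorter chain than that of compound 3 would lower the number further. As far as these compounds go, what an amine or a carboxylic acid on this chain carbon would give also stays open.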